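The source may hold more compounds than are shown below. What is called first, only, known or untested is meant among the compounds shown, and "the series" means these compounds.

Measured so far:
compound 1 `CCOC(=O)c1cc(CCCOc2c(C)cc(-c3noc(C(F)(F)F)n3)cc2C)on1` — 17200 nM
compound 2 `CCOC(=O)c1cc(CCCOc2ccc(-c3noc(C(F)(F)F)n3)cc2C)on1` — 35100 nM
compound 3 `CCNC(=O)c1cc(CCCOc2c(C)cc(-c3noc(C(F)(F)F)n3)cc2C)on1` — a limit of the assay, > 100000 nM

In an ADME assay on HeLa cells (Homo sapiens) for cytotoxicity, read by crystal violet staining, with a stated time of 72 h (a higher number here means that more compound is tolerated, a lower number that less compound is tolerated), compound 2 holds the highest of the two numbers shown. Compound 1 is its nearest neighbour, reached by a 2.0-fold higher number from compound 1 to compound 2 (0.31 log units; beyond the scatter). For compound 3 this assay gives only a limit, > 100000 nM; this is the only limit among the three values (the limit of > 100000 nM in this assay, at which 1 of the 3 values shown sits).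

The next compound, compound 4 `CCOC(=O)c1cc(CCCOc2ccc(-c3noc(C(F)(F)F)n3)cc2/N=C/N(C)C)on1`, comes from compound 2 by a group of 5 heavy atoms (3 carbon, 2 nitrogen; no ring) in place of one carbon atom, on an aromatic carbon. The group sits on an aromatic carbon of a six-membered aromatic ring of carbon only, ortho to a large group and meta to the 5-(trifluoromethyl)-1,2,4-oxadiazol-3-yl group.

Going by the values given here, two measured steps bear on this change. The step of a 2.0-fold higher number from compound 1 to compound 2 (0.31 log units; beyond the scatter) touched an aromatic methyl on the shared core and moved the number modestly upward. The step of an at least 5.8-fold higher number from compound 1 to compound 3 (0.76 log units; beyond the scatter) changed the carbonyl end and moved it at least modestly upward, ending at a limit. Neither step adds a group of this kind at this place, so a modest upward step, or none beyond the scatter, is expected: a 1.4-fold higher number from compound 2 to compound 4 (0.15 log units; within the scatter). Compound 4 is therefore estimated at 50000 nM, with a range from 20000 nM to 120000 nM.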

Compound 4, half-maximal cytotoxic concentration: > 100000 nM
Compound 4: only a limit was reported (the forecaster's own chance of this, stated with the estimate: 30%); at least 2.0-fold (0.30 log units) between middle value and limit.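

Replacing the methyl on this aromatic carbon with the group of 5 heavy atoms gives an at least 2.8-fold higher number from compound 2 to compound 4 (0.45 log units; beyond the scatter) in this assay. Going by these compounds alone, the only earlier step on this aromatic ring, a 2.0-fold higher number from compound 1 to compound 2 (0.31 log units; beyond the scatter), touched nothing larger than a methyl, so compound 4 is the first to show that this place takes a much larger group with no fall in the number. The value of compound 4, > 100000 nM, is a limit of the assay, and it is now one of two such limits in the set: the limit of > 100000 nM in this assay, at which 2 of the 4 values shown sit.

The compounds shown leave open whether a simple amine or an acetamide on this aromatic carbon would also reach that limit. They also leave open which part of the new group, the double bond or the dimethylamino end, accounts for the step.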